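From a pentyl ether to a cyclopentyl ether

The source may hold more compounds than are shown below. What is called first, only, known or untested is meant among the compounds shown, and "the series" means these compounds.

The measured compounds, all read in an assay on cells with melanin-concentrating hormone receptor 1 (Homo sapiens) as the target, read by radioligand binding; a higher number here means a weaker inhibitor, a lower number a stronger inhibitor:

Compound 1 `Nc1ccc2cccc(OC3CCC3)c2n1` reaches only the limit of this assay, > 2000 nM.
Compound 2 `Nc1ccc2cccc(OCCC(F)(F)F)c2n1` gives 722 nM.
Compound 3 `CCCCCOc1cccc2ccc(N)nc12` gives 580 nM.

Compound 3 holds the lowest of the two numbers in this assay; its nearest neighbour is compound 2, and the gap is a 1.2-fold lower number from compound 2 to compound 3 (0.10 log units; within the scatter), within the scatter. The value of compound 1 is a limit, so the steps from it can only be given as bounds: an at least 2.7-fold lower number from compound 1 to compound 2 (0.44 log units; beyond the scatter) and an at least 3.4-fold lower number from compound 1 to compound 3 (0.53 log units; beyond the scatter). Thus the pentyl chain of compound 3 and the 3,3,3-trifluoropropyl chain of compound 2 both gave clearly lower numbers than the cyclobutyl ring of compound 1, while the two open chains did not differ beyond the scatter.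

Compound 4 `Nc1ccc2cccc(OC3CCCC3)c2n1` carries cyclopentyl in place of pentyl on an oxygen on an aromatic ring. This change bears on both steps above: a ring returns to the oxygen, as in compound 1, yet it now has the same count of carbons as the pentyl chain of compound 3. The bounded step an at least 3.4-fold lower number from compound 1 to compound 3 (0.53 log units; beyond the scatter) suggests that a ring at this position may cost potency, so compound 4 is expected to give a higher number than compound 3, by about a 1.7-fold higher number from compound 3 to compound 4 (0.24 log units; within the scatter). The estimate for compound 4 in this assay is 1000 nM, with a range from 300 nM to 3000 nM.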

Compound 4, half-maximal inhibitory concentration: > 2000 nM
Compound 4: only a limit was reported; the forecaster's own chance of this, stated with the estimate: 25%; at least 2.0-fold (0.30 log units) between middle value and limit.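

In this assay, cyclopentyl in place of pentyl leaves the count of carbons unchanged yet gives an at least 3.4-fold higher number from compound 3 to compound 4 (0.53 log units; beyond the scatter), so at this oxygen the number is not set by the carbon count alone. Cyclopentyl in place of 3,3,3-trifluoropropyl gives an at least 2.7-fold higher number from compound 2 to compound 4 (0.44 log units; beyond the scatter), and the pattern now covers all the compounds shown, with no exception: the cyclobutyl and cyclopentyl ethers, compound 1 and compound 4, both give higher numbers than the open-chain ethers, compound 2 and compound 3. The value of compound 4 is a limit, as is that of compound 1, so the step between them cannot be read and the two rings cannot be ranked against each other: the limit of > 2000 nM in this assay, at which 2 of the 4 values shown sit.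

As far as these compounds go, it remains open whether a ring at this oxygen can ever match the open chains, for instance a cyclohexyl ring or a cyclopentylmethyl group. From the compounds shown here alone, it is equally open how far the open chains themselves can lower the number, which a longer chain such as heptyl, a branched chain such as isopentyl, or a chain ending in an amine would begin to show.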